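This account rests on a few compounds, and the source may have more. Where it says the series, first, only, none or still open, it means among the compounds named here.

Of the compounds shown here, two sharing one core have been measured so far in a toxicity assay on MT4 cells (Homo sapiens) for cytotoxicity, read by MTT assay (a lower number here means that less compound is tolerated, a higher number that more compound is tolerated), and their numbers lie close together. Compound 1 (`Cc1cc(-c2ccccc2)cc(C)c1Oc1cc(N)nc(Nc2ccc(C#N)cc2)n1`) gives 25600 nM there, and compound 2 (`Cc1ccc(-c2cc(C)c(Oc3cc(N)nc(Nc4ccc(C#N)cc4)n3)c(C)c2)cc1`) gives 10000 nM as the lowest of the two numbers. Among the compounds with values here, the single measured step is a 2.6-fold lower number from compound 1 to compound 2 (0.41 log units; beyond the scatter) for methyl in place of hydrogen on an aromatic carbon, modest but beyond the scatter.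

Compound 3 (`COc1cccc(-c2cc(C)c(Oc3cc(N)nc(Nc4ccc(C#N)cc4)n3)c(C)c2)c1`) has not yet been measured. It departs from compound 2 in one place (3-methoxyphenyl in place of 4-methylphenyl on an aromatic carbon), with 3-methoxyphenyl in place of 4-methylphenyl on an aromatic carbon, meta to two methyl groups and para to a large group. Within the data shown here, only one measured step bears on this change, and no measured compound carries a methoxy group. Judged from a 2.6-fold lower number from compound 1 to compound 2 (0.41 log units; beyond the scatter) as the one guide, a small step without a firm direction is expected in this assay for this swap. The estimated step is a 1.2-fold higher number from compound 2 to compound 3 (0.08 log units; within the scatter) and so none beyond the scatter is expected. Compound 3 is expected at 12000 nM with an estimated range from 4500 nM to 30000 nM as its likely span.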

Compound 3, half-maximal cytotoxic concentration: 19300 nM
Compound 3: the middle estimate sits 1.6-fold (0.21 log units) below what was measured; the range from low to high includes it.
By their numbers in this assay, from the lowest: compounds 2, 3 and 1 (each within the scatter of the next, the first and the last beyond it).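

In this assay, the exchange of 4-methylphenyl for 3-methoxyphenyl comes to a 1.9-fold higher number from compound 2 to compound 3 (0.29 log units; within the scatter), so this aromatic carbon, meta to two methyl groups, accepts the larger group with its one hydrogen-bond acceptor without a separation beyond the scatter. Methoxy in place of hydrogen likewise comes to a 1.3-fold lower number from compound 1 to compound 3 (0.12 log units; within the scatter), so adding this group leaves compound 3 within the scatter of compound 1, while the methyl step, a 2.6-fold lower number from compound 1 to compound 2 (0.41 log units; beyond the scatter), remains the only measured step beyond it. The compounds offer no measured finding that explains these numbers.

With only these two substituted rings, the compounds leave open whether the step beyond the scatter follows from the kind of group or from where it stands on the ring, since the methyl and the methoxy group differ in both respects. They also leave open how this tolerance would read with quite different groups on that ring, such as an amine or a carboxylic acid, or with a longer chain in place of the methoxy group.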